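One Side Chain Swapped on Compound 3

The source may hold more compounds than are shown below. What is called first, only, known or untested is meant among the compounds shown, and "the series" means these compounds.

Three related compounds have so far been tested in a physicochemical assay for solubility, read by nephelometry, measured as kinetic solubility; a lower number here means a less soluble compound, a higher number a more soluble compound. Compound 3 (`CCC/N=C1\S/C(=C\c2ccc(C(=O)NCC(=O)N(C)C)cc2)C(=O)N1c1ccccc1O`) gives 219000 nM. Compound 2 (`CCC/N=C1\S/C(=C\c2ccc(OC[C@H](O)CO)c(Cl)c2)C(=O)N1c1ccccc1O`) gives 219000 nM, the same number, and compound 1 (`CCC/N=C1\S/C(=C\c2ccc(C(=O)OCCO)cc2)C(=O)N1c1ccccc1C`) gives 110000 nM. All three values lie within the usual scatter of repeated measurements, so compound 3 stands level with compound 2 and cannot be told apart from compound 1.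

Compound 4 (`CCC/N=C1\S/C(=C\c2ccc(C(=O)OCC3COC(=O)O3)cc2)C(=O)N1c1ccccc1O`) has not yet been measured. It keeps the core of compound 3 but has (2-oxo-1,3-dioxolan-4-yl)methoxy in place of ((dimethylcarbamoyl)methyl)amino on a carbonyl carbon. Among the measured compounds shown here, no two tested compounds differ in one place only, so no measured step guides this change. The nearest hint is compound 1, which also has an ester on that carbonyl carbon and gives 110000 nM, though it differs from compound 4 elsewhere too. A small fall, no larger than the scatter, is expected, estimated as a 1.8-fold lower number from compound 3 to compound 4 (0.26 log units; within the scatter). For compound 4 the estimated value is 120000 nM, with an expected range from 40000 nM to 250000 nM.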

Compound 4, solubility: 79000 nM
Compound 4: middle estimate off by 1.5-fold (0.18 log units), on the high side; the measured number falls inside the stated range.
By their numbers in this assay, from the lowest: compounds 4, 1, 2 and 3 (each within the scatter of the next, the first and the last beyond it).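

In this assay, among the compounds shown here, this is the first comparison in which only one place changes: replacing ((dimethylcarbamoyl)methyl)amino with (2-oxo-1,3-dioxolan-4-yl)methoxy on a carbonyl carbon gives a 2.8-fold lower number from compound 3 to compound 4 (0.44 log units; beyond the scatter), a modest step beyond the scatter. For the compounds shown here, it shows that the read-out can respond to what sits at this position, which the earlier compounds could not show because each pair differed in more than one place. Nothing measured here explains the step.

The swap alters the linking atom and adds a five-membered ring together, so this one step cannot separate the two changes. From the compounds shown here alone, how a simple methoxy, a carboxylic acid or a longer chain on that carbonyl carbon would read on the core of compound 3 remains open.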